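Dichlorophenyl for Methylphenyl on a Triazole Nitrogen

A few compounds are considered here, and "the series" means these few. Any claim that something is new, unique, unknown or untested is made for them only; others in the source may bear on it.

Compound 1 `N#CC1=C(N)Oc2c(c3nc4ccccc4nc3c3ccccc23)C12C(=O)N(Cc1cnnn1-c1ccccc1Cl)c1ccccc12`: > 50000 nM
Compound 2 `Cc1cccc(-n2nncc2CN2C(=O)C3(C(C#N)=C(N)Oc4c(N)cc5nc6ccccc6nc5c43)c3ccccc32)c1`: > 50000 nM

Two spiro compounds have been tested in a functional assay on HCT-116 cells (Homo sapiens) for antiproliferative activity, read by MTT assay, with a stated time of 48 h; a higher number here means a weaker inhibitor, a lower number a stronger inhibitor. Compound 1 reached only the limit of this assay, > 50000 nM. Compound 2 likewise sits at the limit, > 50000 nM, and no number is known for it. Both values rest at the limit of > 50000 nM in this assay, at which 2 of the 2 values shown sit.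

Compound 3 `N#CC1=C(N)Oc2c(N)cc3nc4ccccc4nc3c2C12C(=O)N(Cc1cnnn1-c1ccc(Cl)cc1Cl)c1ccccc12` remains unmeasured. It differs from compound 2 by 2,4-dichlorophenyl in place of 3-methylphenyl on an aromatic nitrogen. With both known values being limits, no step can be read from the data. The step of a number no higher from compound 2 to compound 3 (the limit leaves the size open) is expected to stay within the scatter, so compound 3 is estimated at 50000 nM, between 15000 nM and 200000 nM, most likely again reported only as a limit.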

Compound 3, half-maximal inhibitory concentration: > 50000 nM
Compound 3 ended at the assay's limit; the forecaster's own chance of this, stated with the estimate: 75%; the middle value lies on the limit itself.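

In this assay compound 3 gives > 50000 nM, a limit and not a number. Among the compounds shown here, compound 2 also stands at a limit, and no step between compound 2 and compound 3 can be read. The compounds shown leave open whether 2,4-dichlorophenyl and 3-methylphenyl differ at all in this assay.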